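Swapping fluoro for methoxy on the aryl of compound 1

A few compounds are considered here, and "the series" means these few. Any claim that something is new, unique, unknown or untested is made for them only; others in the source may bear on it.

Compound 1 `COc1cccc(CN(NC(=O)NCCCN2CCN(c3ccccc3OC)CC2)c2ccc(F)cc2)c1` is one of two measured compounds in this small set. In an assay on CHO cells for displacement of a labelled ligand from D(4) dopamine receptor (Homo sapiens), read by radioligand binding (on this read-out lower numbers stand for stronger inhibition and higher numbers for weaker inhibition), compound 1 gives 5.9 nM. Compound 2 `COc1ccccc1N1CCN(CCCNC(=O)NN(Cc2ccc(-c3ccccc3)cc2)c2ccc(F)cc2)CC1` gives 5.9 nM in this assay, so the two stand level, and the step of no change at the digits printed from compound 1 to compound 2 (within the scatter), which puts 4-phenylphenyl in place of 3-methoxyphenyl on a saturated chain carbon bound to a nitrogen on an aromatic ring, leaves the value where it was. Compound 3 `COc1ccc(N(Cc2cccc(OC)c2)NC(=O)NCCCN2CCN(c3ccccc3OC)CC2)cc1` has not been measured. It differs from compound 1 by a single change: methoxy in place of fluoro on an aromatic carbon. Among the measured compounds shown here, no measured step touches this part of the molecule; the only known step sits on a different ring and showed no change. For the measured compounds named here, with no direct precedent, only a small step is expected. The step from compound 1 to compound 3 is estimated as a 1.4-fold higher number from compound 1 to compound 3 (0.13 log units; within the scatter). Compound 3 is expected to give 8 nM, within a range of 3 nM to 25 nM.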

Compound 3, inhibition constant: 33 nM
Compound 3: the middle estimate sits 4.1-fold (0.62 log units) below what was measured; the measured number lies above the stated range.
By their numbers in this assay, from the lowest: compounds 1 and 2 (each within the scatter of the next); then compound 3.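

In this assay the change from 4-fluorophenyl to 4-methoxyphenyl, para to a large group, gives a 5.6-fold higher number from compound 1 to compound 3 (0.75 log units; beyond the scatter) and so means weaker inhibition. Among the compounds shown here, the only earlier step, no change at the digits printed from compound 1 to compound 2 (within the scatter) on a different ring, left the value level, so this is the first sign in the set that one small swap can move the number, and it shows that this position is not indifferent to the group it carries. Nothing at hand explains why the number rises with methoxy here.

Only fluoro and methoxy are shown at this position, so it remains open whether the rise follows methoxy in particular or any group other than fluoro, which a chloro, methyl or hydroxyl group there could help settle. As far as these compounds go, it is also open whether the same swap would have the same size with the 4-phenylphenyl group of compound 2 in place.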